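The compounds below may be only part of what the source reports. "The series", "measured", "known", "first", "only" and "open" are said of these compounds alone.

Compound 1 `CC1(C)[C@H]2CC[C@]1(C)N(Cc1cn(-c3cccc(Cl)c3)nn1)C(=O)C2` carries a 3-chlorophenyl group on the triazole of a shared core. In a functional assay on HepG2 cells (Homo sapiens) for inhibition, read by MTT assay, with a stated time of 24 h (a lower number here means a stronger inhibitor, a higher number a weaker inhibitor), compound 1 gives 60 nM, the lowest of the three numbers shown, though every step to its neighbours stays within the scatter. Compound 3 `CC1(C)[C@H]2CC[C@]1(C)N(Cc1cn(-c3ccccc3)nn1)C(=O)C2`, with a plain phenyl, gives 90 nM in this assay, and compound 2 `COc1ccccc1-n1cc(CN2C(=O)C[C@@H]3CC[C@@]2(C)C3(C)C)nn1`, with 2-methoxyphenyl, gives 110 nM in this assay. The steps are small: a 1.5-fold higher number from compound 1 to compound 3 (0.18 log units; within the scatter), a 1.8-fold higher number from compound 1 to compound 2 (0.26 log units; within the scatter) and a 1.2-fold lower number from compound 2 to compound 3 (0.09 log units; within the scatter).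

Compound 4 `CC1(C)[C@H]2CC[C@]1(C)N(Cc1cn(-c3cccc(O)c3)nn1)C(=O)C2` differs from compound 1 by hydroxy in place of chloro on an aromatic carbon. For the measured compounds named here, the steps that bear on this are the removal of chloro from compound 1 to compound 3 and the swap of one ring substituent from compound 1 to compound 2; both stayed within the scatter, so a change at this ring position has so far moved the number little. No change beyond the scatter is therefore expected, perhaps a slightly higher number. Compound 4 is expected to give 90 nM in this assay, within 40 nM to 220 nM, an estimated step of a 1.5-fold higher number from compound 1 to compound 4 (0.18 log units; within the scatter).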

Compound 4, half-maximal inhibitory concentration: 70 nM
The estimate for compound 4 lay 1.3-fold (0.11 log units) above the measured number; low and high end bracket the measured number.
By their numbers in this assay, from the lowest: compounds 1, 4, 3 and 2 (each within the scatter of the next).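

The hydroxy group brings a hydrogen-bond donor and acceptor that chloro lacks, yet in this assay the swap gives only a 1.2-fold higher number from compound 1 to compound 4 (0.07 log units; within the scatter) on this ring carbon. Hydroxy in place of hydrogen gives a 1.3-fold lower number from compound 3 to compound 4 (0.11 log units; within the scatter) and 3-hydroxyphenyl in place of 2-methoxyphenyl gives a 1.6-fold lower number from compound 2 to compound 4 (0.20 log units; within the scatter), so compounds 1, 2, 3 and 4 all lie within the scatter of one another, whether the ring carries chloro, hydroxy, methoxy or no substituent. Nothing available explains this lack of separation.

As far as these compounds go, it remains open whether an amine or a carboxylic acid at this ring carbon would also stay within the scatter of compound 1. A longer chain, such as ethoxy or propoxy, is equally untested by the compounds shown.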